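The compounds below may be only part of what the source reports. "The series", "measured", "known", "first", "only" and "open" are said of these compounds alone.

In a functional assay on Vero cells (Chlorocebus sabaeus) for cytotoxicity, read by MTT assay (a lower number here means that less compound is tolerated, a higher number that more compound is tolerated), compound 2 `CCOC(=O)c1cn(COCCO)c2ccc(F)cc2c1=O` gives only a limit, > 500000 nM. Compound 1 `CCOC(=O)c1cn(COCCO)c2ccc(OC)cc2c1=O` likewise reaches only a limit in this assay, > 500000 nM. The step between them, a step that the two limits leave unreadable from compound 1 to compound 2, cannot be sized, since (the limit of > 500000 nM in this assay, at which 2 of the 2 values shown sit). Compound 3 `CCOC(=O)c1cn(COCCO)c2ccc(Cl)cc2c1=O` has not yet been tested in this assay; it differs from compound 2 by chloro in place of fluoro on an aromatic carbon. Going by the values given here, no measured step gives a readable size for a change of this kind, and both known compounds sit at the limit, so no shift beyond the scatter is expected. Compound 3 is expected to give about 500000 nM, between 200000 nM and 2000000 nM, most likely again only as a limit, which means an expected step of a number no higher from compound 2 to compound 3 (the limit leaves the size open).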

Compound 3, half-maximal cytotoxic concentration: 1250000 nM
The estimate for compound 3 lay 2.5-fold (0.40 log units) below the measured number; the range from low to high includes it.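

Going by these compounds alone, no step to compound 3 can be sized, from compound 1 or from compound 2, since those two compounds give only limits: the limit of > 500000 nM in this assay, at which 2 of the 3 values shown sit. As far as these compounds go, how far methoxy, fluoro and chloro truly differ in this assay stays open.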